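The compounds below may be only part of what the source reports. "The series", "measured", "known", "first", "only" and "open" are said of these compounds alone.

In a functional assay on HFF cells (Homo sapiens) for cytotoxicity, read by neutral red uptake (a higher number here means that more compound is tolerated, a lower number that less compound is tolerated), compound 1 `COC(OC)c1cn(C2C[C@H](OC(C)=O)[C@@H](COC(C)=O)O2)c(=O)[nH]c1=O` gives > 300000 nM, which is a limit and not a number. Compound 2 `COC(OC)c1cn(C2C[C@H](O)[C@@H](CO)O2)c(=O)[nH]c1=O` gives > 300000 nM, also a limit. Compound 3 `O=c1[nH]c(=O)n(C2C[C@H](O)[C@@H](CO)O2)cc1C1OCCO1` gives > 300000 nM, again a limit. The whole series thus rests on (the limit of > 300000 nM in this assay, at which 3 of the 3 values shown sit), and compound 1 stands there with it. Compound 4 `CC(=O)OC[C@H]1OC(n2cc(C3OCCCO3)c(=O)[nH]c2=O)C[C@@H]1OC(C)=O` keeps the core of compound 1 and changes one group on an aromatic carbon: a group of 6 heavy atoms (4 carbon, 2 oxygen; one six-membered non-aromatic ring with 2 hetero atoms) in place of a group of 5 heavy atoms (3 carbon, 2 oxygen; no ring), on an aromatic carbon. Within the data shown here, the one measured step that bears on this, a step that the two limits leave unreadable from compound 2 to compound 3, also replaces dimethoxymethyl, and its size cannot be read. No step beyond the scatter is therefore expected in this assay. The estimated a number no higher from compound 1 to compound 4 (the limit leaves the size open) is expected to stay within the scatter. Compound 4 is expected at 300000 nM, with an estimated range of 150000 nM to 600000 nM.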

Compound 4, half-maximal cytotoxic concentration: > 300000 nM
Compound 4: only a limit was reported; the forecaster's own chance of this, stated with the estimate: 90%; the middle value sits exactly at the limit.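

No step can be read between compound 1 and compound 4, since both give only a limit: the limit of > 300000 nM in this assay, at which 4 of the 4 values shown sit. The compounds shown leave open where any of them truly lies in this assay and whether any change of group matters there.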